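The source may report more compounds than this note shows. Statements on the series, on what has been measured and on what is new or still open speak of the compounds shown alone.

Compound 1, `CC1=CC[C@H](C(C)(C)N=C=S)CC1`. In a functional assay on NCI/ADR-RES cells (Homo sapiens) for inhibition, read by sulforhodamine B assay, with a stated time of 48 h (a lower number here means a stronger inhibitor of growth, a higher number a weaker inhibitor of growth), compound 1 gives > 100000 nM, a limit of the assay rather than a number.
Compound 2, `CC1=CC[C@H](C(C)(C)NC(=S)NN)CC1`. In this assay compound 2 gives > 100000 nM, again a limit and not a number.
Compound 3, `COc1ccc(/C=N/NC(=S)NC(C)(C)[C@H]2CC=C(C)CC2)cc1`. In this assay compound 3 gives 50400 nM.

For the measured compounds named here, compound 3 therefore stands as the only compound of the three with a measured number; the other two sit at the limit of > 100000 nM in this assay, at which 2 of the 3 values shown sit. Going by the values given here, the one recorded step between measured compounds, a step that the two limits leave unreadable from compound 1 to compound 2, cannot be read in size, since both ends of it are limits.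

Compound 4, `CC1=CC[C@H](C(C)(C)NC(=S)N/N=C/c2ccc(F)cc2)CC1`, differs from compound 3 by fluoro in place of methoxy on an aromatic carbon. Among the compounds with values here, none of the measured steps bears on this change: the only step on record is unreadable, and it concerns a different part of the molecule. With nothing in the data pointing either way, the step from compound 3 to compound 4 is expected to be a 1.0-fold lower number from compound 3 to compound 4 (0.00 log units; within the scatter), that is, none beyond the scatter. Compound 4 is therefore estimated at 50000 nM in this assay, with a range from 20000 nM to 100000 nM.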

Compound 4, concentration for total growth inhibition: > 100000 nM
Compound 4: a limit, no number; the forecaster's own chance of this, stated with the estimate: 30%; at least 2.0-fold (0.30 log units) between middle value and limit.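

Fluoro in place of methoxy gives the first step in this series that has a measured number at one end, and it reads an at least 1.9-fold higher number from compound 3 to compound 4 (0.29 log units; that floor lies within the scatter). That size is only a floor, and the floor itself lies within the scatter, so the step does not establish that compound 4 is the weaker inhibitor of growth, though swapping in fluoro does not bring a stronger number. Compound 4 gives a limit of the assay and not a number, which leaves compound 3 as the only compound with a measured value: the limit of > 100000 nM in this assay, at which 3 of the 4 values shown sit.

Going by these compounds, how far the true value of compound 4 lies from that of compound 3 remains open. So does the reading at this place on the aromatic ring for other groups, such as hydrogen, chloro, hydroxyl or an amine.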